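The source may report more compounds than this note shows. Statements on the series, on what has been measured and on what is new or still open speak of the compounds shown alone.

- compound 1 `CN1CCCCC1CCO/N=C1C(=C2/C(=O)Nc3ccc(F)cc32)/Nc2ccccc2/1`: 600 nM
- compound 2 `CN(C)CCCO/N=C1C(=C2/C(=O)Nc3ccccc32)/Nc2ccccc2/1`: 610 nM

Both compounds were tested in a functional assay on A549 cells (Homo sapiens) for cytotoxicity, read by MTT assay, with a stated time of 72 h; a higher number here means a weaker inhibitor, a lower number a stronger inhibitor. There, compound 2 gives 610 nM, which is level with compound 1 at 600 nM, since the gap between them lies within the scatter of repeated measurements.

The next compound to be tested is compound 3 `CN1CCCC1CCO/N=C1C(=C2/C(=O)Nc3ccccc32)/Nc2ccccc2/1`. It has 1-methylpyrrolidin-2-yl in place of (dimethylamino)methyl on a saturated chain carbon, two bonds along the chain from an oxygen on an unsaturated carbon.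

Among the compounds with values here, no measured pair shows what this exchange alone does in this assay. Within the data shown here, the only guide is that the two values so far sit together, so no change beyond the scatter is expected. The expected size of a 1.2-fold lower number from compound 2 to compound 3 (0.09 log units; within the scatter) is correspondingly small. For compound 3 the estimated value is 500 nM, with an expected range from 200 nM to 1300 nM.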

Compound 3, half-maximal inhibitory concentration: 260 nM
Compound 3: middle estimate off by 1.9-fold (0.28 log units), on the high side, and the stated range covers the measured number.
By their numbers in this assay, from the lowest: compound 3; then compounds 1 and 2 (each within the scatter of the next).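

In this assay, replacing the open (dimethylamino)methyl group with the ring-containing 1-methylpyrrolidin-2-yl gives a 2.3-fold lower number from compound 2 to compound 3 (0.37 log units; beyond the scatter) on the same core. Within the data shown here, this is the first single exchange that can be read, and it shows that the group on this saturated chain carbon, two bonds along the chain from an oxygen on an unsaturated carbon, can move the number beyond the scatter, although the hydrogen-bond donor and acceptor counts stay the same. No measurement presented here explains the change.

As far as these compounds go, it remains open whether the ring itself matters, or only the larger group, and whether a morpholine or a pyrrolidine without the methyl on nitrogen would fit here as well. The same exchange on a core carrying fluorine also remains untested by any pair shown.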